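Ethyl to isopropyl on a thioester phenol core

A few compounds are considered here, and "the series" means these few. Any claim that something is new, unique, unknown or untested is made for them only; others in the source may bear on it.

Measured compounds:
compound 1 `CCc1c(O)c(C)c(O[C@@H]2O[C@H](CO)[C@@H](O)[C@H](O)[C@H]2O)c(C(=O)SC)c1C(C)C` — > 40000 nM
compound 2 `Cc1c(O)c(C)c(C(C)C)c(O[C@@H]2O[C@H](CO)[C@@H](O)[C@H](O)[C@H]2O)c1O` — > 40000 nM
compound 3 `CCc1c(C)c(O)c(C)c(O)c1C(=O)SC` — > 40000 nM

In a functional assay on HCT-116 cells (Homo sapiens) for cytotoxicity, read by sulforhodamine B assay, with a stated time of 72 h (a lower number here means a stronger inhibitor, a higher number a weaker inhibitor), compound 1 reaches only a limit, > 40000 nM, and not a number. In this assay compound 2 likewise gives only a limit, > 40000 nM. Compound 3 stands at the same place: in this assay it is reported as a limit, > 40000 nM, with no number behind it. All three values shown thus sit at one point, as summarised by the limit of > 40000 nM in this assay, at which 3 of the 3 values shown sit, so none of the three can be set apart from the others.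

Compound 4 `CSC(=O)c1c(O)c(C)c(O)c(C)c1C(C)C` is not yet measured in this assay. It differs from compound 3 by one change: methyl in place of hydrogen on a saturated chain carbon bound to an aromatic carbon and a saturated chain carbon. The shared core, its two hydroxyl groups, its two methyl groups and its thioester are untouched.

For the measured compounds named here, since compound 3 gives only a limit, > 40000 nM, there is no measured step from which the size of this change can be read. The expected step of a number no higher from compound 3 to compound 4 (the limit leaves the size open) is therefore none beyond the scatter, and compound 4 is expected to come out at 40000 nM, within a range from 15000 nM to 100000 nM, most probably again as a limit rather than a number.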

Compound 4, half-maximal inhibitory concentration: 3900 nM
Estimate against measurement, compound 4: 10-fold (1.01 log units) above; the measured number lies below the stated range.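

The earlier compounds shown here gave no number at all, and this pair shows that the chain carbon bound to the aromatic carbon is a place where a small change registers in this assay: going from ethyl to isopropyl, which adds a single carbon, gives an at least 10-fold lower number from compound 3 to compound 4 (1.01 log units; beyond the scatter). Compound 4 is thus the one compound shown that gives a number rather than a limit: the limit of > 40000 nM in this assay, at which 3 of the 4 values shown sit. The reading holds for this single pair only: the isopropyl group also stands in compound 1, which differs from compound 4 in more than one place, and compound 1 is reported as a limit, > 40000 nM.

As far as these compounds go, compound 3 is itself only a limit, and the true size of the step stays open. Also open, from the compounds shown here alone, is whether a tert-butyl group, a cyclopropyl ring or a longer chain such as butyl at this place would take the number lower still or lose it again, and how an amine on the same chain would read.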